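Lipophilicity notes: replacing the bicyclic aryl on the chloropyridine

The source may hold more compounds than are shown below. What is called first, only, known or untested is meant among the compounds shown, and "the series" means these compounds.

Measured so far:
compound 1 `CC(=O)N[C@@H]1CCC[C@H](C(=O)Nc2cc(-c3cnn4c3CCCC4)ccn2)C1`: 2.4
compound 2 `CC(=O)N[C@@H]1CCC[C@H](C(=O)Nc2cc(-c3cnc4ccccn34)c(Cl)cn2)C1`: 3

Going by the values given here, in a physicochemical assay for lipophilicity, using the shake flask method, measured as octanol-water partition, at pH 7.4 (on this read-out higher numbers stand for higher lipophilicity and lower numbers for lower lipophilicity), compound 2 gives 3, the higher of the two numbers recorded; the only other compound, compound 1, gives 2.4, and that gap lies beyond the scatter. Among the compounds with values here, no step between compounds that differ in a single place is available, so the two values can only be set side by side.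

Compound 3 `CC(=O)N[C@@H]1CCC[C@H](C(=O)Nc2cc(-c3cnn4c3OCCC4)c(Cl)cn2)C1` has not yet been run in this assay. Relative to compound 2 it carries a group of 9 heavy atoms (6 carbon, 2 nitrogen, 1 oxygen; one five-membered aromatic ring with 2 hetero atoms, one six-membered non-aromatic ring with 2 hetero atoms) in place of a group of 9 heavy atoms (7 carbon, 2 nitrogen; one five-membered aromatic ring with 2 hetero atoms, one six-membered aromatic ring with 1 hetero atom), on an aromatic carbon. The change sits on an aromatic carbon of a six-membered aromatic ring with one nitrogen, ortho to the chloro group, meta to a large group and opposite the ring nitrogen. The chloro group of compound 2 is kept.

Taking compound 1 at 2.4 and compound 2 at 3 as the only reference points, a downward step of moderate size is expected, a number 0.50 log units lower from compound 2 to compound 3 (beyond the scatter), somewhat larger than the scatter. Compound 3 is therefore estimated at 2.5, within 2 to 3.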

Compound 3, distribution coefficient: 2.6
For compound 3 the middle estimate is 0.10 log units below the measured one; the measured number falls inside the stated range.
By their numbers in this assay, from the lowest: compounds 1 and 3 (each within the scatter of the next); then compound 2.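

In this assay, the exchange on an aromatic carbon of the six-membered aromatic ring with one nitrogen, ortho to the chloro group and with that chloro group kept, gives a number 0.40 log units lower from compound 2 to compound 3 (beyond the scatter). Going by these compounds alone, this is the first single-place reading, and it shows that the read-out responds to the group at this position even though the group leaving and the group entering each count 9 heavy atoms. The exchange alters several things at once, with an oxygen entering, a six-membered non-aromatic ring with 2 hetero atoms replacing a six-membered aromatic ring with 1 hetero atom, and the group of compound 2 counting 2 hydrogen-bond acceptors where the group of compound 3 counts 3 hydrogen-bond acceptors, and nothing at hand ties the step to any one of these differences.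

Compound 1 differs from compound 2 and from compound 3 in more than one place, so the contribution of the chloro group cannot be read on its own. Also open, from the compounds shown here alone, is how the read-out would respond to a fluoro group or a nitrile in place of the chloro group, or to an amine on the entering six-membered ring.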